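From ethyl to hydroxy on compound 2

The source may report more compounds than this note shows. Statements on the series, on what has been measured and on what is new or still open speak of the compounds shown alone.

Values in a functional assay on MDA-MB-231 cells (Homo sapiens) for inhibition, read by MTT assay, with a stated time of 48 h; on this read-out higher numbers stand for weaker inhibition of growth and lower numbers for stronger inhibition of growth:
- Compound 1 `S=C(NCc1ccccc1)Nc1ccc2ncnc(Nc3ccccc3Br)c2c1`: > 30000 nM (a limit of the assay, not a number)
- Compound 2 `CCc1cccc(Nc2ncnc3ccc(NC(=S)NCc4ccccc4)cc23)c1`: 10500 nM
- Compound 3 `S=C(NCc1ccccc1)Nc1ccc2ncnc(Nc3ccc(-c4ccccc4)cc3)c2c1`: 8400 nM

Going by the values given here, only two of these values are true numbers. Compound 2, at 10500 nM, and compound 3, at 8400 nM, lie within the usual scatter of each other.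

The next compound is compound 4 `Oc1cccc(Nc2ncnc3ccc(NC(=S)NCc4ccccc4)cc23)c1`. It carries hydroxy in place of ethyl on an aromatic carbon, meta to a large group (hydroxy in place of ethyl on an aromatic carbon).

Among the compounds with values here, only one measured step touches this aryl group: an at least 2.8-fold lower number from compound 1 to compound 2 (0.45 log units; beyond the scatter), with 3-ethylphenyl in place of 2-bromophenyl on a nitrogen on an aromatic ring. That step shows that changing this group can shift the read-out, but it swaps a different pair of groups. Hydroxy has not been measured on any compound here, so the step gives no direction for the new change. No shift beyond the scatter is therefore expected in this assay, although the uncertainty is wide.

The expected step is a 1.1-fold lower number from compound 2 to compound 4 (0.02 log units; within the scatter).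

Compound 4 is estimated at 10000 nM, with an expected range from 3500 nM to 30000 nM.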

Compound 4, concentration for 50% growth inhibition: > 30000 nM
Compound 4 ended at the assay's limit (the forecaster's own chance of this, stated with the estimate: 15%); middle value at least 3.0-fold (0.47 log units) away from the limit.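

In this assay, hydroxy in place of ethyl gives an at least 2.8-fold higher number from compound 2 to compound 4 (0.45 log units; beyond the scatter) and so weaker inhibition of growth. The earlier step on this aryl group swapped 2-bromophenyl for 3-ethylphenyl, so both the group and its place changed, whereas here the place stays the same and only the group differs. As far as these compounds go, that single change on this aromatic carbon is enough to move the read-out beyond the scatter, but compound 4 gives only a limit of the assay, > 30000 nM, so the full size of the step stays unknown.

Compound 1 and compound 4 both end at limits, and the step between them cannot be read: the limit of > 30000 nM in this assay, at which 2 of the 4 values shown sit. Also open, from the compounds shown here alone, is how a methoxy group, an amine or a longer chain on this same aromatic carbon would compare with ethyl and hydroxy.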